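The compounds below may be only part of what the source reports. "The series", "measured", "known", "first", "only" and "open" are said of these compounds alone.

The series shares one core, carried by compound 1 `CC1CCN(c2c(S(=O)(=O)c3ccccc3)cnc3ccccc23)CC1`, in which a four-methylpiperidinyl group sits on the core. In an assay on isolated protein for displacement of a labelled ligand from metabotropic glutamate receptor 5 (Homo sapiens), with a stated time of 60 min (a lower number here means a stronger inhibitor, a higher number a weaker inhibitor), compound 1 gives 108 nM. Two further members vary the same ring. Compound 2 `CCN1CCN(c2c(S(=O)(=O)c3ccccc3)cnc3ccccc23)CC1` bears an ethylpiperazinyl group, and in this assay compound 2 stands at "not determined" (no result reported), so no number is available for it. Compound 3 `NC(=O)C1CCN(c2c(S(=O)(=O)c3ccccc3)cnc3ccccc23)CC1` carries a carbamoyl group on the saturated ring, and in this assay compound 3 likewise stands at "not determined" (no result reported). Among the compounds with values here, compound 3 therefore has no place on the numerical scale: the only number in the set belongs to compound 1, and no comparison of compound 3 with it can be made.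

The step from compound 3 leads to compound 4 `O=S(=O)(c1ccccc1)c1cnc2ccccc2c1N1CCCCC1`, which carries the plain piperidinyl group. The change is hydrogen in place of carbamoyl on a saturated ring carbon, in short hydrogen in place of carbamoyl on a saturated ring carbon. Within the data shown here, no step between measured compounds exists against which this change could be weighed, and the starting point has no number, so the direction and size of the step cannot be predicted from the set. The nearest reference is compound 1 with its 108 nM, whose ring differs from that of compound 4 only by the methyl group. On that basis compound 4 is expected to lie near 200 nM, within a range from 60 nM to 700 nM.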

Compound 4, inhibition constant: 307 nM
Beside the measured number, compound 4's estimate is 1.5-fold (0.19 log units) below it; the measured number falls inside the stated range.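

Hydrogen in place of methyl on the saturated ring carbon gives a 2.8-fold higher number from compound 1 to compound 4 (0.45 log units; beyond the scatter) in this assay, which supplies the first measured step in the set and shows that the number changes with what this carbon, three ring bonds from the ring nitrogen, carries. Of the two compounds, compound 1 with its methyl group is the stronger inhibitor, and compound 4 now serves as the unsubstituted reference for this ring. The change from 4-carbamoylpiperidin-1-yl to piperidin-1-yl cannot be read, and neither can any other step involving compound 2 or compound 3, since neither compound has a number; no measurement is at hand that would explain the step from methyl to hydrogen.

A single methyl group therefore says nothing about how the number would move with an ethyl or a longer chain, a hydroxyl group, an amine or a carboxylic acid on the same ring carbon. Going by these compounds, it also remains open how a piperazine ring, with its second ring nitrogen, would compare with the piperidine of compound 4.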